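A few compounds are considered here, and "the series" means these few. Any claim that something is new, unique, unknown or untested is made for them only; others in the source may bear on it.

In a functional assay on HepG2 cells (Homo sapiens) for antiproliferative activity, read by MTT assay, with a stated time of 48 h (on this read-out higher numbers stand for weaker inhibition and lower numbers for stronger inhibition), compound 3 `CN1CCN(CCCCOc2c(OCc3ccccc3)cc3oc(-c4ccccc4)cc(=O)c3c2O)CC1` gives 2500 nM and compound 1 `CN1CCN(CCCOc2c(OCc3ccccc3)cc3oc(-c4ccccc4)cc(=O)c3c2O)CC1` gives 2400 nM, so the two stand level within the scatter. Compound 2 `O=c1cc(-c2ccccc2)oc2cc(O)c(OCCCCN3CCCC3)c(O)c12` reports only a limit, > 100000 nM. Compound 4 `O=c1cc(-c2ccccc2)oc2cc(OCc3ccccc3)c(OCCCCN3CCCC3)c(O)c12` differs from compound 3 in one place, with pyrrolidin-1-yl in place of 4-methylpiperazin-1-yl on a saturated chain carbon, four bonds along the chain from an oxygen on an aromatic ring. Within the data shown here, the one measured step, a 1.0-fold higher number from compound 1 to compound 3 (0.02 log units; within the scatter), alters the chain and keeps 4-methylpiperazin-1-yl, so it bears only indirectly, and no measured step exchanges that group. In this assay, the expected result is a 1.2-fold higher number from compound 3 to compound 4 (0.08 log units; within the scatter), with no shift beyond the scatter anticipated. For compound 4 the estimate is 3000 nM, with an expected range from 1000 nM to 10000 nM.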

Compound 4, half-maximal inhibitory concentration: 2000 nM
Compound 4: the middle estimate sits 1.5-fold (0.18 log units) above what was measured, and the stated range covers the measured number.
By their numbers in this assay, from the lowest: compounds 4, 1 and 3 (each within the scatter of the next). At a limit, above all of these: compound 2.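

In this assay, pyrrolidin-1-yl in place of 4-methylpiperazin-1-yl on the chain leaves the read-out level (a 1.3-fold lower number from compound 3 to compound 4 (0.10 log units; within the scatter)), and the comparison with the shorter chain also stays within the scatter (a 1.2-fold lower number from compound 1 to compound 4 (0.08 log units; within the scatter)), so compounds 1, 3 and 4 show that either ring is accepted here. Benzyl in place of hydrogen on an oxygen on an aromatic ring matters far more (an at least 50-fold lower number from compound 2 to compound 4 (1.69 log units; beyond the scatter)). Compound 2 gives a limit and not a number: the limit of > 100000 nM in this assay, at which 1 of the 4 values shown sits.

Still open, as far as these compounds go, is whether an open-chain amine such as diethylamino or a carboxylic acid at the chain end would hold the read-out. Also open, from the compounds shown here alone, is whether methyl on that oxygen would do what benzyl does.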